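A few compounds are considered here, and "the series" means these few. Any claim that something is new, unique, unknown or untested is made for them only; others in the source may bear on it.

Four compounds share one amide-linked scaffold and are compared in an ADME assay on HEK-293T cells (Homo sapiens) for cytotoxicity, read by CCK-8 assay, with a stated time of 48 h; a higher number here means that more compound is tolerated, a lower number that less compound is tolerated. Compound 1 has the structure `CCOc1ccccc1NC(=O)CSc1c[nH]c2c(Cl)cccc12`. Compound 2, with the structure `CCOc1ccccc1NC(=O)CSc1c[nH]c2c(OC)cccc12`, differs from it by a single change: methoxy in place of chloro on an aromatic carbon. Compound 3 has the structure `CCOc1ccccc1NC(=O)CSc1c[nH]c2cccc(Cl)c12` and carries the same atoms as compound 1, joined differently; the difference between the two cores is not broken down here. Compound 4, not yet measured, has the structure `CCOc1ccccc1NC(=O)CSc1c[nH]c2cccc(OC)c12`, and the way it differs from compound 3 is methoxy in place of chloro on an aromatic carbon. The words describing the place of that change match those for the change from compound 1 to compound 2 exactly, so the same change is made twice among these compounds.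

In this assay compound 1 gives > 100000 nM, which is a limit of the assay and not a number. Compound 2 likewise gives > 100000 nM, again a limit. For this reason the step that the two limits leave unreadable from compound 1 to compound 2 cannot be read as a size, due to the limit of > 100000 nM in this assay, at which 2 of the 3 values shown sit. Among the compounds with values here, compound 3 gives 25200 nM, the only finished number among the three measured compounds.

Within the data shown here, since the one earlier instance of the change leaves its size unreadable, the expectation for compound 4 rests mainly on compound 3 and its value 25200 nM, with the step of a 1.6-fold higher number from compound 3 to compound 4 (0.20 log units; within the scatter) estimated to be modest. Compound 4 is therefore expected to give about 40000 nM, between 15000 nM and 150000 nM.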

Compound 4, half-maximal cytotoxic concentration: > 100000 nM
Compound 4 was reported as a limit (the forecaster's own chance of this, stated with the estimate: 35%); middle value at least 2.5-fold (0.39 log units) away from the limit.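

In this assay, methoxy in place of chloro on the core of compound 3 gives an at least 3.9-fold higher number from compound 3 to compound 4 (0.59 log units; beyond the scatter), so on this core the change goes with more compound being tolerated. Compound 4 gives > 100000 nM, which is a limit of the assay and not a number. This does not show that the change acts the same way on every core, as the step from compound 1 to compound 2 cannot be read and so neither supports nor contradicts the step seen here, due to a shared limit: the limit of > 100000 nM in this assay, at which 3 of the 4 values shown sit.

Open, on these data alone, is whether the higher number on the core of compound 3 goes with methoxy itself or only with the departure of chloro, a question that a plain hydrogen, an amine or a hydroxyl group at the same place could help to answer. Also open, as far as these compounds go, is how far the two cores truly differ, which would take a group at this place that gives a finished number on both the core of compound 1 and the core of compound 3.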